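The compounds below may be only part of what the source reports. "The series", "measured", "known", "first", "only" and "open" are said of these compounds alone.

Three compounds share one core and differ only in the length of a saturated chain. Compound 1 `CCCCCCCCCOC(=O)CCC(=O)N1CCN(CCCOc2cc3c(Nc4ccc(F)c(Cl)c4)ncnc3cc2OC)CC1` gives 10.3% in a functional assay on A549 cells (Homo sapiens) for cytotoxicity, read by MTT assay, with a stated time of 24 h, tested at 60 uM; a lower number here means a stronger effect, a higher number a weaker effect of the compound at the concentration tested. Compound 2 `CCCCCCCCCCCCOC(=O)CCC(=O)N1CCN(CCCOc2cc3c(Nc4ccc(F)c(Cl)c4)ncnc3cc2OC)CC1` gives 2% in this assay, and compound 3 `CCCCCCCCCCCCCCCCCCCOC(=O)CCC(=O)N1CCN(CCCOc2cc3c(Nc4ccc(F)c(Cl)c4)ncnc3cc2OC)CC1` gives 89.3% in this assay, the highest of the three numbers and so the weakest effect among them. The steps between them show that a number 8.3 percentage points lower from compound 1 to compound 2 (within the scatter), whereas a number 79 percentage points higher from compound 1 to compound 3 (beyond the scatter) and a number 87.3 percentage points higher from compound 2 to compound 3 (beyond the scatter). Compound 4 `CCCCCCCCCCCCCCCCCCCCOC(=O)CCC(=O)N1CCN(CCCOc2cc3c(Nc4ccc(F)c(Cl)c4)ncnc3cc2OC)CC1` has not yet been measured. It differs from compound 3 by methyl in place of hydrogen on a saturated chain carbon, ten or more bonds along the chain from an oxygen next to a carbonyl group. The steps that lengthened the chain bear on it: the two large ones entered a decyl and a heptyl, while the one that entered a propyl stayed within the scatter. Since compound 4 lengthens the longest chain by only a methyl, the step of a number 1.3 percentage points lower from compound 3 to compound 4 (within the scatter) is expected to be small, with no change beyond the scatter in this assay. Compound 4 is therefore estimated at 88%, within a range from 70% to 100%.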

Compound 4, a percentage reported as activity, at one concentration (the size of the read-out at that concentration, not a potency): 86.9%
The estimate for compound 4 lay 1.1 percentage points above the measured number; the measured number falls inside the stated range.
By their numbers in this assay, from the lowest: compounds 2 and 1 (each within the scatter of the next); then compounds 4 and 3 (each within the scatter of the next).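

Adding a methyl on a saturated chain carbon gives a number 2.4 percentage points lower from compound 3 to compound 4 (within the scatter) in this assay, so compound 4 sits with compound 3 at the weak end of the series. Compound 4 also stands far from the shorter chains, with a number 84.9 percentage points higher from compound 2 to compound 4 (beyond the scatter) and a number 76.6 percentage points higher from compound 1 to compound 4 (beyond the scatter). The weak effect seen with compound 3 is therefore no longer a single result, as a second long-chain compound now shares it.

Nothing measured here explains why these longer chains give the weaker effect. Also open, going by these compounds, are where along the lengths between compound 2 and compound 3 the effect is lost, and how a chain ending in an amine or a carboxylic acid would behave.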